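The source may hold more compounds than are shown below. What is called first, only, known or untested is meant among the compounds shown, and "the series" means these compounds.

Compound 1 `O=C1C=C(NCc2ccccc2)C(=O)c2c1nc1n2[C@H]2OC[C@@H](O)[C@H]2OC1` carries benzyl on the amine nitrogen of the shared core. In a functional assay on HeLa cells (Homo sapiens) for inhibition, read by sulforhodamine B assay (a higher number here means a weaker inhibitor, a lower number a stronger inhibitor), compound 1 gives only a limit, > 8000 nM, so its place among the numbers shown cannot be fixed. Compound 1 sits at the limit of > 8000 nM in this assay, at which 1 of the 3 values shown sits. Compound 2 `CCOc1ccccc1NC1=CC(=O)c2c(nc3n2[C@H]2OC[C@@H](O)[C@H]2OC3)C1=O` carries 2-ethoxyphenyl on the amine nitrogen, and in this assay compound 2 gives 8300 nM. Compound 3 `O=C1C(NCc2ccccc2)=CC(=O)c2c1nc1n2[C@H]2OC[C@@H](O)[C@H]2OC1` is the benzyl counterpart of compound 2, and in this assay compound 3 gives 11000 nM. Going by the values given here, the step of a 1.3-fold higher number from compound 2 to compound 3 (0.12 log units; within the scatter) is the only measured exchange of an aryl for a benzyl on the amine nitrogen, and it lies within the scatter.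

Compound 4 `O=C1C=C(Nc2ccc(Br)cc2)C(=O)c2c1nc1n2[C@H]2OC[C@@H](O)[C@H]2OC1` differs from compound 1 by 4-bromophenyl in place of benzyl on an amine nitrogen. Given that the measured step from compound 2 to compound 3 stayed within the scatter, no shift beyond the scatter is expected for a step that the limit leaves unreadable from compound 1 to compound 4. Compound 4 is therefore expected to lie near the limit, estimated at 9000 nM with a range from 5000 nM to 16000 nM.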

Compound 4, half-maximal inhibitory concentration: 3830 nM
Compound 4: middle estimate off by 2.3-fold (0.37 log units), on the high side; the measured number lies below the stated range.
By their numbers in this assay, from the lowest: compound 4; then compounds 2 and 3 (each within the scatter of the next).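

In this assay, the amine nitrogen on the core of compound 1 responds to its substituent: 4-bromophenyl in place of benzyl gives an at least 2.0-fold lower number from compound 1 to compound 4 (0.31 log units; beyond the scatter). The only earlier readable exchange at an amine nitrogen, a 1.3-fold higher number from compound 2 to compound 3 (0.12 log units; within the scatter), stayed within the scatter, so exchanging benzyl and an aryl group does not shift the number beyond the scatter in every case shown. The true size of the new step remains unknown because compound 1 carries only a limit: the limit of > 8000 nM in this assay, at which 1 of the 4 values shown sits.

The compounds shown leave open whether the lower number belongs to the bromine or to the aryl ring set directly on the nitrogen. Unsubstituted phenyl would separate these two readings, while 4-chlorophenyl or 4-methoxyphenyl would test how far the result depends on the bromine.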